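The source may report more compounds than this note shows. Statements on the series, on what has been measured and on what is new or still open speak of the compounds shown alone.

Measured compounds:
- compound 1, `COc1ccc(-n2cc(COc3c(/C=C\C(=O)O)ccc(OC)c3CC=C(C)C)nn2)cc1`: "not determined" (no result reported) in a functional assay on T47D cells (Homo sapiens) for cytotoxicity, read by MTT assay, with a stated time of 24 h; on this read-out higher numbers stand for weaker inhibition and lower numbers for stronger inhibition
- compound 2, `COc1ccc(/C=C\C(=O)O)c(OCc2cn(-c3cccc([N+](=O)[O-])c3)nn2)c1CC=C(C)C`: 15400 nM
- compound 3, `COc1ccccc1-n1cc(COc2c(/C=C\C(=O)O)ccc(OC)c2CC=C(C)C)nn1`: "not determined" (no result reported) in this assay

All three share one core, a cinnamic acid carrying a prenyl chain and a methoxy group, linked through a triazole to an aryl ring that differs from compound to compound. Only compound 2, with a 3-nitrophenyl on the triazole, has a number in this assay, and that number is a weak one. Compound 1 stands nowhere on the numbers shown: it was tested, but no result came back, and the same is true of compound 3. So nothing can be said about how the aryl ring on the triazole nitrogen moves cytotoxicity within this set.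

Compound 4, `COc1cccc(-n2cc(COc3c(/C=C\C(=O)O)ccc(OC)c3CC=C(C)C)nn2)c1`, differs from compound 1 in one place (3-methoxyphenyl in place of 4-methoxyphenyl on an aromatic nitrogen). Among the compounds with values here, no step between measured compounds covers this kind of change, so no size or direction can be read from the data; the only anchor is the weak value of compound 2, which carries the same 3-substituted pattern on its aryl ring. On that basis compound 4 is expected to be weak as well in this assay, estimated at 18000 nM with a likely range from 6000 nM to 55000 nM.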

Compound 4, half-maximal inhibitory concentration: 20400 nM
Beside the measured number, compound 4's estimate is 1.1-fold (0.05 log units) below it, within the range that was stated.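

In this assay, within the data shown here, putting methoxy in place of nitro on an aromatic carbon of the ring attached to the aromatic nitrogen gives a 1.3-fold higher number from compound 2 to compound 4 (0.12 log units; within the scatter), so this is the first direct comparison at this ring, and it finds no difference that can be told from ordinary assay scatter. Within this single pair, the two groups are interchangeable for this cytotoxicity read-out, even though they are quite different substituents by name. Nothing in the information available explains this result or links it to any property of the two groups.

From the compounds shown here alone, the steps from compound 4 to compound 1 and to compound 3 cannot be read, as neither of those compounds has a number, so it remains open whether moving the methoxy group around the ring changes cytotoxicity at all. Also open, going by these compounds, is whether an amine or a carboxylic acid on this ring, or a longer chain such as ethoxy in place of the methoxy group, would shift the value beyond the scatter.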